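Compound 3 in the Middle, and a Larger Group

The compounds below may be only part of what the source reports. "The series", "measured", "known", "first", "only" and "open" are said of these compounds alone.

Of the compounds shown here, three sharing one core have been measured in a functional assay on MCF7 cells (Homo sapiens) for inhibition, read by MTT assay, with a stated time of 48 h; a higher number here means a weaker inhibitor, a lower number a stronger inhibitor. There, compound 1 (`CCOC(=O)C1=C(N/C=N/c2cccnc2Cl)Nc2[nH]nc(C)c2C1c1ccc(N(C)C)cc1`) gives 4180 nM, compound 2 (`CCOC(=O)C1=C(N/C=N/c2nnc(S(N)(=O)=O)s2)Nc2[nH]nc(C)c2C1c1ccc(N(C)C)cc1`) gives 34500 nM and compound 3 (`CCOC(=O)C1=C(NN=C(C#N)C#N)Nc2[nH]nc(C)c2C1c1ccc(N(C)C)cc1`) gives 12100 nM. That puts compound 3 in the middle of the three numbers.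

The next molecule is compound 4 (`CCOC(=O)C1=C(N/N=C(/Cl)c2ccc([N+](=O)[O-])cc2)Nc2[nH]nc(C)c2C1c1ccc(N(C)C)cc1`), which keeps the core and changes one side group: a group of 12 heavy atoms (7 carbon, 2 nitrogen, 2 oxygen, 1 chlorine; one six-membered aromatic ring of carbon only) in place of a group of 6 heavy atoms (3 carbon, 3 nitrogen; no ring), on an amine nitrogen. The entering group brings a six-membered aromatic ring of carbon only, and the group it replaces has no ring.

Two measured steps changed the group at this same place: a 2.9-fold higher number from compound 1 to compound 3 (0.46 log units; beyond the scatter) and a 2.9-fold lower number from compound 2 to compound 3 (0.46 log units; beyond the scatter). Both are modest, and they are a reminder that ring-bearing groups here have landed on either side of compound 3. Compound 2 goes against any simple rule, since its ring-bearing group gives a higher number than compound 3 does. Among the measured groups, the one in compound 1, at 4180 nM, is the closest match, with a six-membered aromatic ring and a chlorine. A small move toward a lower number is therefore expected, and the estimated step is a 1.5-fold lower number from compound 3 to compound 4 (0.18 log units; within the scatter). Compound 4 is estimated at 8000 nM, with an expected range from 3000 nM to 25000 nM.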

Compound 4, half-maximal inhibitory concentration: 52700 nM
For compound 4 the middle estimate is 6.6-fold (0.82 log units) below the measured one; the measured number lies above the stated range.
By their numbers in this assay, from the lowest: compound 1; then compound 3; then compounds 2 and 4 (each within the scatter of the next).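

The carbon-only aromatic ring entering at this amine nitrogen makes compound 4 a weaker inhibitor in this assay than compound 3, with a 4.4-fold higher number from compound 3 to compound 4 (0.64 log units; beyond the scatter), so this ring-bearing group falls on the weak side, unlike the pyridine-type group of compound 1. The contrast with compound 1 is the widest gap so far, with a 13-fold higher number from compound 1 to compound 4 (1.10 log units; beyond the scatter), even though both groups carry a six-membered aromatic ring and a chlorine, which shows that these shared features do not on their own keep the number low here. Compound 4 also cannot be separated from compound 2, with a 1.5-fold higher number from compound 2 to compound 4 (0.18 log units; within the scatter), so two quite different ring-bearing groups end up at the weak end, and nothing available explains why these groups differ.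

The groups differ from one another in several features at once, so the separate contributions of ring type, chlorine and group size remain unresolved. Also open, on these data alone, is how this carbon-only ring would behave at this position with an amine or a carboxylic acid on it in place of its two-oxygen nitrogen group.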